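The source may hold more compounds than are shown below. What is called first, only, known or untested is meant among the compounds shown, and "the series" means these compounds.

Working notes on the series. Compound 1 `O=C(N[C@H]1CCOC[C@@H]1O)c1cn(Cc2ccc(-n3cccn3)cc2)c2cccnc12` stands on the numbers shown only as a limit. In an ADME assay on liver for metabolic stability, with Liver microsome (Homo sapiens) as the target, using microsomes (a lower number here means slower removal, a higher number faster removal of the compound), compound 1 gives < 8 mL/min/kg, which is a limit of the assay and not a number (the limit of < 8 mL/min/kg in this assay, at which 1 of the 3 values shown sits). Compound 2 `O=C(N[C@H]1CCOC[C@@H]1O)c1cn(Cc2ccc(-c3cc[nH]n3)cc2)c2cccnc12` gives 9.2 mL/min/kg in this assay. Compound 3 `O=C(N[C@H]1CCCC[C@@H]1O)c1cn(Cc2ccc3ncccc3c2)c2cccnc12` gives 87 mL/min/kg in this assay. Within the data shown here, the single measured step, an at least 1.1-fold higher number from compound 1 to compound 2 (0.06 log units; that floor lies within the scatter), concerns the aromatic side and not the amide side; no measured step changes the amide substituent alone. The step to compound 4 `O=C(N[C@H]1CC[C@H](CO)CC1)c1cn(Cc2ccc(-n3cccn3)cc2)c2cccnc12` is 4-(hydroxymethyl)cyclohexyl in place of 3-hydroxyoxan-4-yl on an amide-type nitrogen. Compound 4 is therefore expected to give a moderately higher number, an at least 1.8-fold higher number from compound 1 to compound 4 (0.27 log units; that floor lies within the scatter), with wide uncertainty. The estimate for compound 4 in this assay is 15 mL/min/kg, within a range of 6 mL/min/kg to 45 mL/min/kg.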

Compound 4, clearance: 8.5 mL/min/kg
Beside the measured number, compound 4's estimate is 1.8-fold (0.25 log units) above it, within the range that was stated.
By their numbers in this assay, from the lowest: compounds 4 and 2 (each within the scatter of the next); then compound 3. At a limit, below all of these: compound 1.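

Among these compounds, this is the only measured step that changes the amide substituent alone, with 4-(hydroxymethyl)cyclohexyl in place of 3-hydroxyoxan-4-yl on an amide-type nitrogen and the rest of the compound kept. In this assay the step reads as an at least 1.0-fold higher number from compound 1 to compound 4 (0.02 log units; that floor lies within the scatter), so the swap of the oxygen-containing ring for a carbon-only ring shows no change beyond the scatter. Compound 1 remains a limit of the assay and not a number: the limit of < 8 mL/min/kg in this assay, at which 1 of the 4 values shown sits.

As far as these compounds go, the true size of the step stays open. Also open, from the compounds shown here alone, is how an amine or a carboxylic acid in place of the hydroxymethyl group would read in this assay.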